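A few compounds are considered here, and "the series" means these few. Any claim that something is new, unique, unknown or untested is made for them only; others in the source may bear on it.

Measured in a functional assay on SMMC-7721 cells (Homo sapiens) for cytotoxicity, read by MTT assay, with a stated time of 24 h; on this read-out lower numbers stand for stronger inhibition and higher numbers for weaker inhibition:
- compound 1 `O=C1/C(=C/c2cccnc2)CN(S(=O)(=O)c2ccc(Br)cc2)C/C1=C\c1ccccc1C(F)(F)F`: 5760 nM
- compound 2 `CC(=O)Nc1ccc(S(=O)(=O)N2C/C(=C\c3cccnc3)C(=O)/C(=C/c3ccccc3C(F)(F)F)C2)cc1`: 9830 nM

Compound 1 stands within the scatter of compound 2, so neither holds a clear rank in this assay. Compound 3 `O=C1/C(=C/c2ccncc2)CN(S(=O)(=O)c2ccc(Br)cc2)C/C1=C\c1ccccc1C(F)(F)F` differs from compound 1 by pyridin-4-yl in place of pyridin-3-yl on a double-bonded chain carbon bound to a double-bonded ring carbon, with pyridin-4-yl in place of pyridin-3-yl on a double-bonded chain carbon bound to a double-bonded ring carbon. Going by the values given here, no measured step touches this place. The only one, a 1.7-fold higher number from compound 1 to compound 2 (0.23 log units; within the scatter), is acetamido in place of bromo on an aromatic carbon, and it stays within the scatter. No step beyond the scatter is therefore expected in this assay. The expected change is a 1.0-fold higher number from compound 1 to compound 3 (0.00 log units; within the scatter). The estimate for compound 3 is 5800 nM, with an expected range from 2500 nM to 13000 nM.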

Compound 3, half-maximal inhibitory concentration: 10500 nM
For compound 3 the middle estimate is 1.8-fold (0.26 log units) below the measured one; the measured number falls inside the stated range.
By their numbers in this assay, from the lowest: compounds 1, 2 and 3 (each within the scatter of the next).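

Pyridin-4-yl in place of pyridin-3-yl, on a double-bonded chain carbon bound to a double-bonded ring carbon, is the first change shown at this place, and in this assay it gives a 1.8-fold higher number from compound 1 to compound 3 (0.26 log units; within the scatter). Moving the attachment point of the pyridine ring therefore leaves no readable difference in this assay. Nothing at hand bears on what lies behind these numbers.

As far as these compounds go, it remains open whether pyridin-2-yl, a plain phenyl ring or a ring carrying an amine at this place would give a step beyond the scatter.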